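Cyclopropyl for methyl on a sulfonyl: solubility outlook

The compounds below may be only part of what the source reports. "The series", "measured", "known", "first", "only" and "open" are said of these compounds alone.

Compound 1, `CS(=O)(=O)c1cncc(-c2cnc3ccc(-c4cccc(S(=O)(=O)C5CC5)c4)nn23)c1`, in a physicochemical assay for solubility, at pH 6.5 (a lower number here means a less soluble compound, a higher number a more soluble compound), gives < 5000 nM, which is a limit of the assay and not a number.
Compound 2, `NC(=O)c1ccc(-c2cnc3ccc(-c4cccc(S(=O)(=O)C5CC5)c4)nn23)cc1`, gives < 5000 nM, again a limit of the assay.
Compound 3, `CS(=O)(=O)c1cccc(-c2ccc3ncc(-c4ccc(S(C)(=O)=O)nc4)n3n2)c1`, gives < 5000 nM, also a limit of the assay.

Compound 3 therefore stands at the lower edge of what this assay reports, and nothing in the three values places it above or below either of the other two compounds. For the measured compounds named here, the single measured step, a step that the two limits leave unreadable from compound 1 to compound 2, cannot be read, since both of its ends are limits. The one thing the data do show is the limit of < 5000 nM in this assay, at which 3 of the 3 values shown sit.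

Compound 4, `CS(=O)(=O)c1ccc(-c2cnc3ccc(-c4cccc(S(=O)(=O)C5CC5)c4)nn23)cn1`, differs from compound 3 by cyclopropyl in place of methyl on a sulfonyl sulfur. Going by the values given here, no measured step touches a substituent on a sulfonyl sulfur, and the only measured step is unreadable, so no direction or size beyond the scatter can be drawn from the steps themselves. The expectation for compound 4 rests on compound 3 alone, due to the limit of < 5000 nM in this assay, at which 3 of the 3 values shown sit, sitting where all three values sit. Compound 4 is estimated to give about 2000 nM, within 300 nM to 8000 nM. The step from compound 3 to compound 4 is expected to be a step that the limit leaves unreadable from compound 3 to compound 4, and the result is expected to come back most likely as a limit again rather than as a number.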

Compound 4, solubility: < 5000 nM
Compound 4 gave a limit, no number; the forecaster's own chance of this, stated with the estimate: 80%; the middle value is on the limit's open side.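

Compound 4 gives < 5000 nM, which is a limit of the assay and not a number. Every step from compound 1, compound 2 and compound 3 to compound 4 therefore has a limit at both ends, and none of them can be read. The compounds shown leave open how soluble each one actually is in this assay, and whether cyclopropyl in place of methyl on a sulfonyl sulfur makes any difference there.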